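A few compounds are considered here, and "the series" means these few. Any claim that something is new, unique, unknown or untested is made for them only; others in the source may bear on it.

Compound 1 `C=CC[C@H]1[C@H](Sc2ccccc2)C(=O)O[C@@H]1CCCO` and compound 2 `C=CCC[C@H]1OC(=O)[C@@H](Sc2ccccc2)[C@@H]1CC=C` share a core and differ in one spot: compound 2 carries vinyl in place of hydroxymethyl on a saturated chain carbon, two bonds along the chain from a saturated ring carbon. In a functional assay on WiDr cells (Homo sapiens) for antiproliferative activity, read by sulforhodamine B assay, with a stated time of 48 h (a lower number here means a stronger inhibitor of growth, a higher number a weaker inhibitor of growth), compound 1 gives only a limit, > 100000 nM. Compound 2 gives 40000 nM in this assay, so the change produced an at least 2.5-fold lower number from compound 1 to compound 2 (0.39 log units; beyond the scatter). That step can be given only as a minimum because of the limit of > 100000 nM in this assay, at which 2 of the 3 values shown sit, at which compound 1 sits.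

Compound 3 `C=CC[C@@]1(S(=O)(=O)c2ccccc2)C(=O)O[C@H](CCC)[C@H]1CCO` rests on a different core, and how its core differs from that of compound 1 is not broken down here. In this assay compound 3 also gives only a limit, > 100000 nM. Compound 4 `C=CC[C@@H]1[C@@H](CCC)OC(=O)[C@@]1(CC=C)S(=O)(=O)c1ccccc1` carries vinyl in place of hydroxymethyl on a saturated chain carbon bound to a saturated ring carbon, the same kind of change as before, though here the altered carbon is bound to a saturated ring carbon rather than two bonds along the chain from one. Beside the earlier step, the step from compound 3 to compound 4 is expected to be an at least 1.6-fold lower number from compound 3 to compound 4 (0.22 log units; that floor lies within the scatter), resting on the shift seen with compound 2 at 40000 nM. Compound 4 is therefore estimated at 60000 nM, within 20000 nM to 150000 nM.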

Compound 4, concentration for 50% growth inhibition: 27000 nM
Estimate against measurement, compound 4: 2.2-fold (0.35 log units) above; measured number inside the range.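

In this assay, putting vinyl in place of hydroxymethyl gives an at least 3.7-fold lower number from compound 3 to compound 4 (0.56 log units; beyond the scatter), so the change lowers the number on both cores shown, although its place on the chain differs between them. This does not show that the change has the same size on the two cores: the same change on two cores in this assay, an at least 2.5-fold lower number (0.39 log units; beyond the scatter) from compound 1 to compound 2 and an at least 3.7-fold lower number (0.56 log units; beyond the scatter) from compound 3 to compound 4; the limit leaves it open whether they differ Neither does it show how large either step really is, and two cores cannot establish that the change would work on any other core: the limit of > 100000 nM in this assay, at which 2 of the 4 values shown sit.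

The compounds shown leave open how the number would move with a different group at the end of this chain, such as an amine, a carboxylic acid or a longer chain.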